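Replacing the 4-(dimethylamino)piperidin-1-yl group in compound 2

The compounds below may be only part of what the source reports. "The series", "measured", "known", "first", "only" and "open" are said of these compounds alone.

Measured so far:
compound 1 `CN1CCN(Nc2cccc3c2C[C@@H](CN(C)[C@H]2CCCc4cccnc42)NC3)CC1`: 21%
compound 2 `CN(C)C1CCN(c2cccc3c2C[C@H](CN(C)[C@H]2CCCc4cccnc42)NC3)CC1`: 52.4%
compound 3 `CN(C[C@H]1Cc2c(cccc2N[C@H]2CC[C@H](N)CC2)CN1)[C@H]1CCCc2cccnc21`: 75%

In an ADME assay on microsomes from liver (Rattus norvegicus) for metabolic stability, using NADPH, with a stated time of 10 min (on this read-out higher numbers stand for a more stable compound and lower numbers for a less stable compound), compound 2 stands at 52.4% as the second highest of the three numbers, under compound 3 and over compound 1. Compound 4 `CN1C[C@@H]2CN(c3cccc4c3C[C@H](CN(C)[C@H]3CCCc5cccnc53)NC4)C[C@@H]2C1` differs from compound 2 by a group of 9 heavy atoms (7 carbon, 2 nitrogen; 2 five-membered non-aromatic rings with 1 hetero atom each) in place of a group of 9 heavy atoms (7 carbon, 2 nitrogen; one six-membered non-aromatic ring with 1 hetero atom), on an aromatic carbon and has not yet been measured. For the measured compounds named here, the one measured step bearing on this change is a number 22.6 percentage points higher from compound 2 to compound 3 (beyond the scatter) and it is modest, but it brings in a different group, (4-aminocyclohexyl)amino. Going by the values given here, no measured compound carries the entering group, so the data give no direction. The estimated step is a number 2.4 percentage points lower from compound 2 to compound 4 (within the scatter) and it is expected to stay within the scatter. In this assay compound 4 is expected at 50% (range 30% to 70%).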

Compound 4, percent of the compound remaining: 35.3%
Compound 4: the middle estimate sits 14.7 percentage points above what was measured; low and high end bracket the measured number.
By their numbers in this assay, from the lowest: compound 1; then compound 4; then compound 2; then compound 3.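

With two five-membered non-aromatic rings in place of 4-(dimethylamino)piperidin-1-yl, this assay shows a number 17.1 percentage points lower from compound 2 to compound 4 (beyond the scatter), so this position distinguishes between groups that match in heavy atoms and hydrogen-bond acceptors. Against (4-aminocyclohexyl)amino, the same group gives a number 39.7 percentage points lower from compound 3 to compound 4 (beyond the scatter), which widens the spread of values at this aromatic carbon. Nothing available explains either drop. The compounds shown leave open how a morpholine or a pyrrolidine bearing a dimethylamino group would compare with compound 2 and compound 4.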